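A few compounds are considered here, and "the series" means these few. Any claim that something is new, unique, unknown or untested is made for them only; others in the source may bear on it.

Going by the values given here, compound 1 `COc1ccc2c(=O)c(/C=C/C(=O)NCc3cccc(F)c3)coc2c1` gives 17600 nM in a functional assay on HeLa cells (Homo sapiens) for inhibition, read by MTT assay, with a stated time of 48 h (on this read-out lower numbers stand for stronger inhibition and higher numbers for weaker inhibition), and is the only compound here with an actual number. Compound 2 `COc1ccc2c(=O)c(/C=C/C(=O)NCc3ccccc3F)coc2c1` reaches only the assay limit of > 100000 nM in this assay. The step of an at least 5.6-fold higher number from compound 1 to compound 2 (0.75 log units; beyond the scatter) shows that changes at this end of the molecule can matter. Compound 3 `COc1cccc(NC(=O)/C=C/c2coc3cc(OC)ccc3c2=O)c1` differs from compound 1 at that same end: 3-methoxyphenyl in place of 3-fluorobenzyl on an amide-type nitrogen. Among the compounds with values here, no measured step covers this change, so the direction is uncertain, and a mild weakening is expected as the best guess, a 1.7-fold higher number from compound 1 to compound 3 (0.23 log units; within the scatter). Compound 3 is therefore estimated at 30000 nM, within 8000 nM to 100000 nM.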

Compound 3, half-maximal inhibitory concentration: 19200 nM
For compound 3 the middle estimate is 1.6-fold (0.19 log units) above the measured one, and the stated range covers the measured number.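

Replacing 3-fluorobenzyl with 3-methoxyphenyl on the amide-type nitrogen leaves the number essentially unchanged: a 1.1-fold higher number from compound 1 to compound 3 (0.04 log units; within the scatter). The same replacement starting from 2-fluorobenzyl gives a clear difference: an at least 5.2-fold lower number from compound 2 to compound 3 (0.71 log units; beyond the scatter). The value of compound 2, > 100000 nM, is a limit of the assay and not a number.

This swap changes fluorine to methoxy and benzyl to phenyl at once, so the compounds shown leave open what each change does alone; 3-methoxybenzyl or 3-fluorophenyl would separate them. Also open, on these data alone, is how a group carrying an amine or a carboxylic acid would behave on this nitrogen.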